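The source may hold more compounds than are shown below. What is called first, only, known or untested is meant among the compounds shown, and "the series" means these compounds.

Measured so far:
- compound 1, `CCCCCNc1nc(NCc2ccco2)c2cc(F)ccc2n1`: 94.2%
- compound 2, `CCCCCNc1nc(NCc2ccco2)c2ccccc2n1`: "not determined" (no result reported)

Within the data shown here, in a functional assay on HCT-116 cells (Homo sapiens) for cytotoxicity, read by MTT assay, with a stated time of 2 days, tested at 10 uM (on this read-out lower numbers stand for less inhibition and higher numbers for more inhibition at the one concentration tested (going by the name of the read-out)), compound 1 gives 94.2%, the only number so far; compound 2 gives "not determined" (no result reported) in this assay, so nothing can be set beside compound 1. Among the measured compounds shown here, no step between two measured compounds exists here, and the scatter of this read-out is the only yardstick.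

Compound 3, `CCN(CC)CCNc1nc(NCc2ccco2)c2cc(F)ccc2n1`, differs from compound 1 by diethylamino in place of propyl on a saturated chain carbon, two bonds along the chain from a nitrogen on an aromatic ring. For the measured compounds named here, with no measured step of this kind, the size of the effect is open. Compound 1 stands near the top of the scale with 94.2%, which leaves little room upward; the expectation is a step from a number 12.2 percentage points lower from compound 1 to compound 3 (beyond the scatter) that is small to moderate and downward, possibly not beyond the scatter. Compound 3 is therefore expected to give about 82%, within 55% to 98%.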

Compound 3, a percentage reported as inhibition, at one concentration (the size of the read-out at that concentration, not a potency): 26.4%
For compound 3 the middle estimate is 55.6 percentage points above the measured one; the measured number lies below the stated range.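

Replacing propyl with diethylamino on a saturated chain carbon, two bonds along the chain from a nitrogen on an aromatic ring, gives a number 67.8 percentage points lower from compound 1 to compound 3 (beyond the scatter) in this assay, so this part of the chain is not indifferent to the group it carries. Among these compounds, as the only readable step, it shows that the high reading of compound 1 does not carry over to every chain on the shared core. Nothing available here accounts for the size of this step.

Going by these compounds, whether the same drop would follow with a pyrrolidine or a hydroxyl group at the chain end, or with a longer chain ending in diethylamino, remains open. Steps to compound 2 cannot be read, as it has no reported number.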